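One aromatic ring exchanged, from compound 3 to compound 4

The source may hold more compounds than are shown below. What is called first, only, known or untested is meant among the compounds shown, and "the series" means these compounds.

Compound 1 `C[C@H](O)[C@@H](CCC1CCCCC1)n1cnc2c(N)ncnc21`: 0.217 h
Compound 2 `COC(=O)c1cccc(CC[C@H]([C@H](C)O)n2cnc3c(N)ncnc32)c1`: > 0.5 h
Compound 3 `C[C@H](O)[C@@H](CCc1cccc(-c2nccs2)c1)n1cnc2c(N)ncnc21`: > 0.5 h

Only compound 1 gives a true number in an ADME assay on microsomes from liver (Rattus norvegicus) for metabolic stability, read by LC-MS, using NADPH, with stated times of 5 min and 30 min, at 37 degrees C (a higher number here means that the compound lasts longer, a lower number that the compound disappears faster), and it reads 0.217 h as a half-life. Compound 2 gives > 0.5 h and that is a limit, not a number. Compound 3 gives > 0.5 h in this assay and that too is only a limit. The picture so far rests on the limit of > 0.5 h in this assay, at which 2 of the 3 values shown sit, and little else.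

Compound 4 `C[C@H](O)[C@@H](CCc1cccc(-c2cnccn2)c1)n1cnc2c(N)ncnc21` differs from compound 3 in one group: pyrazin-2-yl in place of 1,3-thiazol-2-yl on an aromatic carbon of a six-membered aromatic ring of carbon only, meta to a large group. The exchange counts as pyrazin-2-yl in place of 1,3-thiazol-2-yl on an aromatic carbon and the rest of the molecule stays the same.

For the measured compounds named here, the one measured step on that aromatic carbon is a step that the two limits leave unreadable from compound 2 to compound 3 and with no size to carry over from it, no step beyond the usual scatter is expected in this assay and no direction can be named. The expected step is a number no higher from compound 3 to compound 4 (the limit leaves the size open) in this estimate. A limit is a likely report for compound 4 as well. For compound 4 the estimated value is 0.5 h with an expected range of 0.25 h to 1 h as the half-life.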

Compound 4, half-life: > 0.5 h
Compound 4: no number, only a limit (the forecaster's own chance of this, stated with the estimate: 65%); the middle value lies on the limit itself.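

In this assay compound 4 gives > 0.5 h and that is a limit, not a number. No step among compound 2, compound 3 and compound 4 can be read, as all three stop at the same limit: the limit of > 0.5 h in this assay, at which 3 of the 4 values shown sit.

The compounds shown leave open how long compound 2, compound 3 and compound 4 actually last, and so whether exchanging the group on that aromatic carbon changes the half-life at all.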